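This account rests on a few compounds, and the source may have more. Where it says the series, first, only, none or still open, it means among the compounds named here.

Compound 1 `O=C(Nc1ccc(Oc2ccnc3[nH]ccc23)cc1)c1nn(-c2ccccc2)ccc1=O`: 15600 nM
Compound 2 `O=C(Nc1ccc(Oc2ccnc3[nH]ccc23)cc1)c1nn(-c2ccc(Cl)c(C(F)(F)F)c2)ccc1=O`: 6270 nM

Going by the values given here, in a functional assay on MCF7 cells (Homo sapiens) for cytotoxicity, read by MTT assay, with a stated time of 72 h (on this read-out lower numbers stand for stronger inhibition and higher numbers for weaker inhibition), compound 2 gives 6270 nM, the lowest of the two numbers, and the only measured step, a 2.5-fold lower number from compound 1 to compound 2 (0.40 log units; beyond the scatter), concerns the aryl group on the pyridazinone nitrogen. Compound 3 `Cn1ccc2c(Oc3ccc(NC(=O)c4nn(-c5ccc(Cl)c(C(F)(F)F)c5)ccc4=O)cc3)ccnc21` differs from compound 2 by methyl in place of hydrogen on an aromatic nitrogen. Among the compounds with values here, no measured step touches that position, so no shift beyond the scatter is expected: the step is estimated as a 1.3-fold higher number from compound 2 to compound 3 (0.11 log units; within the scatter). Compound 3 is therefore expected to give about 8000 nM, within 3000 nM to 25000 nM.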

Compound 3, half-maximal inhibitory concentration: 15200 nM
Beside the measured number, compound 3's estimate is 1.9-fold (0.28 log units) below it, and the stated range covers the measured number.
By their numbers in this assay, from the lowest: compound 2; then compounds 3 and 1 (each within the scatter of the next).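

In this assay, methyl in place of hydrogen on the aromatic nitrogen gives a 2.4-fold higher number from compound 2 to compound 3 (0.38 log units; beyond the scatter), the first measured sign that this position of the shared core is not indifferent to substitution. Here, the change goes towards weaker inhibition, and compound 2, with its hydrogen on this nitrogen, keeps the lower number. No available evidence accounts for this step. The compounds shown leave open whether an ethyl group or a longer chain on this nitrogen would move the number further. They also leave open how a chain ending in an amine would behave there.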